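Replacing 4-chlorophenyl with methyl across two related cores

The compounds below may be only part of what the source reports. "The series", "measured", "known", "first", "only" and "open" are said of these compounds alone.

Measured compounds:
compound 1, `O=C(Nc1nnc(-c2cccc(O)c2O)s1)c1ccc(Cl)cc1`: 9500 nM
compound 2, `O=C(Nc1nnc(-c2ccc(O)c(O)c2)s1)c1ccc(Cl)cc1`: 14600 nM
compound 3, `CC(=O)Nc1nnc(-c2cccc(O)c2O)s1`: 200000 nM

These three compounds were tested in a functional assay on A549 cells (Homo sapiens) for cytotoxicity, read by MTT assay, with a stated time of 72 h; on this read-out lower numbers stand for stronger inhibition and higher numbers for weaker inhibition. Compound 1 and compound 2 are built from the same atoms joined differently; the difference between the two cores is not broken down here, and the value of compound 1 and the value of compound 2 lie within the scatter of each other. Compound 3 differs from compound 1 by methyl in place of 4-chlorophenyl on a carbonyl carbon, and this change gave a 21-fold higher number from compound 1 to compound 3 (1.32 log units; beyond the scatter), a clear loss of activity.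

Compound 4, `CC(=O)Nc1nnc(-c2ccc(O)c(O)c2)s1`, has not yet been measured. It differs from compound 2 by methyl in place of 4-chlorophenyl on a carbonyl carbon, the same change at the same place. A step of similar size is expected, a 17-fold higher number from compound 2 to compound 4 (1.23 log units; beyond the scatter), because the earlier step of a 21-fold higher number from compound 1 to compound 3 (1.32 log units; beyond the scatter) was large and clear, and compound 2 starts close to where compound 1 started. Compound 4 is therefore estimated at 250000 nM in this assay, most likely between 80000 nM and 600000 nM, with a real chance that only a limit is reported.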

Compound 4, half-maximal inhibitory concentration: 133000 nM
Compound 4: the middle estimate sits 1.9-fold (0.27 log units) above what was measured, and the stated range covers the measured number.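

In this assay, methyl in place of 4-chlorophenyl on a carbonyl carbon gives a 9.1-fold higher number from compound 2 to compound 4 (0.96 log units; beyond the scatter) and so repeats on a second core the loss of activity seen on the first. The two steps point the same way and cannot be told apart in size: the same change on two cores in this assay, a 21-fold higher number (1.32 log units; beyond the scatter) from compound 1 to compound 3 and a 9.1-fold higher number (0.96 log units; beyond the scatter) from compound 2 to compound 4, 2.3-fold (0.36 log units) apart, within the scatter of two such steps. This supports carrying the change between these two closely related cores, but two matched pairs show nothing about other cores in the series and do not explain why the 4-chlorophenyl compounds give the lower numbers.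

The compounds shown leave open whether the ring or its chlorine matters more, since a plain phenyl group does not appear among them. From the compounds shown here alone, it also remains open how a longer chain such as propyl, or a group carrying an amine, would behave on the same carbonyl carbon.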